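The compounds below may be only part of what the source reports. "The series", "measured", "known", "first", "only" and "open" are said of these compounds alone.

Measured in a functional assay on MCF7 cells (Homo sapiens), read by MTT assay, with a stated time of 48 h; a lower number here means a stronger inhibitor, a higher number a weaker inhibitor:
- compound 1 `CCn1c(C(=O)NCCN)ccc1C(CC)(CC)c1ccc(OCC(=O)C(C)(C)C)c(C)c1`: 75 nM
- compound 2 `CCn1c(C(=O)NCCCN(C)C)ccc1C(CC)(CC)c1ccc(OCC(O)C(C)(C)C)c(C)c1`: 490 nM

Compound 2 holds the higher number of the two, beyond the scatter from compound 1. Compound 3 `CCn1c(C(=O)NCCN)ccc1C(CC)(CC)c1ccc(OCC(O)C(C)(C)C)c(C)c1` arises from compound 2 by one change: amino in place of (dimethylamino)methyl on a saturated chain carbon, two bonds along the chain from an amide-type nitrogen. For the measured compounds named here, no single-change step has been measured, so only the gap between the two values guides the expectation: a moderate fall in this assay, probably beyond the scatter but smaller than that gap. The expected step is a 2.5-fold lower number from compound 2 to compound 3 (0.39 log units; beyond the scatter). For compound 3 the estimated value is 200 nM, with an expected range of 70 nM to 600 nM.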

Compound 3, half-maximal inhibitory concentration: 5.9 nM
Beside the measured number, compound 3's estimate is 34-fold (1.53 log units) above it, and the stated range ends above it.
By their numbers in this assay, from the lowest: compound 3; then compound 1; then compound 2.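

Amino in place of (dimethylamino)methyl, on a saturated chain carbon two bonds along the chain from an amide-type nitrogen, gives a large step in this assay (an 83-fold lower number from compound 2 to compound 3 (1.92 log units; beyond the scatter)), so this position is highly sensitive to the change. A second position also responds: 1-hydroxy-2,2-dimethylpropyl in place of (tert-butyl)carbonyl, on a saturated chain carbon bound to an oxygen on an aromatic ring, gives (a 13-fold lower number from compound 1 to compound 3 (1.10 log units; beyond the scatter)). Nothing available accounts for either step.

The 2-aminoethyl chain differs from 3-(dimethylamino)propyl in both length and nitrogen substitution, and these two changes remain unseparated. A 3-aminopropyl or 2-(dimethylamino)ethyl chain would tell them apart.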